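The compounds below may be only part of what the source reports. "The series", "measured", "known", "first", "only" and "open" are said of these compounds alone.

Measured in an ADME assay on Vero cells (Chlorocebus sabaeus) for cytotoxicity, read by MTT assay, with a stated time of 72 h; on this read-out lower numbers stand for higher toxicity in this test and higher numbers for lower toxicity in this test:
compound 1 `CCOC(=O)CN1CCN(c2c(F)cc3c(=O)c(C(=O)O)cn(C4CC4)c3c2OC)CC1C`: 1000 ug/mL
compound 2 `COc1c(N2CCN(CCC(C)=O)C(C)C2)c(F)cc2c(=O)c(C(=O)O)cn(C3CC3)c12`: 9.84 ug/mL
compound 3 `CCO/N=C(\C)CN1CCN(c2c(F)cc3c(=O)c(C(=O)O)cn(C4CC4)c3c2OC)CC1C`: 31.3 ug/mL

Compound 3 holds the second highest of the three numbers. The gaps around it are a 3.2-fold higher number from compound 2 to compound 3 (0.50 log units; beyond the scatter) and a 32-fold lower number from compound 1 to compound 3 (1.50 log units; beyond the scatter). Next in the series is compound 4 `COc1c(N2CCN(C/C(C)=N/NC(N)=O)C(C)C2)c(F)cc2c(=O)c(C(=O)O)cn(C3CC3)c12`, with ureido in place of ethoxy on a double-bonded nitrogen. Among the compounds with values here, no measured step makes this exchange. The large steps of a 100-fold lower number from compound 1 to compound 2 (2.01 log units; beyond the scatter) and a 32-fold lower number from compound 1 to compound 3 (1.50 log units; beyond the scatter) start from the ethoxycarbonyl side chain, so they bear little here. The closest guide is the modest 3.2-fold higher number from compound 2 to compound 3 (0.50 log units; beyond the scatter). The double-bonded nitrogen stays in place, so no step beyond the scatter is expected in this assay. The expected step is a 1.3-fold higher number from compound 3 to compound 4 (0.11 log units; within the scatter). For compound 4 the estimated value is 40 ug/mL, with an expected range of 10 ug/mL to 160 ug/mL.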

Compound 4, half-maximal cytotoxic concentration: 500 ug/mL
Beside the measured number, compound 4's estimate is 13-fold (1.10 log units) below it; the measured number lies above the stated range.
By their numbers in this assay, from the lowest: compound 2; then compound 3; then compounds 4 and 1 (each within the scatter of the next).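

In this assay, the group on the double-bonded nitrogen carries much of the read-out: ureido in place of ethoxy gives a 16-fold higher number from compound 3 to compound 4 (1.20 log units; beyond the scatter), although the double-bonded nitrogen stays in place. The wider side-chain comparisons give a 51-fold higher number from compound 2 to compound 4 (1.71 log units; beyond the scatter) and a 2.0-fold lower number from compound 1 to compound 4 (0.30 log units; within the scatter), which places the ureido side chain within the scatter of the ethoxycarbonyl side chain. Nothing available accounts for this shift.

On these data alone, whether a primary amine or a carboxylic acid on the double-bonded nitrogen would track ureido or ethoxy stays open. So does whether a longer alkoxy chain there would stay with ethoxy.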